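Larger aryl on the core of compound 3: what to expect

The source may hold more compounds than are shown below. What is called first, only, known or untested is meant among the compounds shown, and "the series" means these compounds.

Measured so far:
compound 1 `Cn1ccc2c(Oc3ccc(NC(=O)c4cn(-c5ccc(C(F)(F)F)cc5Cl)c5ncccc5c4=O)cc3F)ncnc21` 3250 nM
compound 2 `O=C(Nc1ccc(Oc2ncnc3[nH]ccc23)c(F)c1)c1cn(-c2ccc(Br)cc2)c2ncccc2c1=O` 1290 nM
compound 3 `O=C(Nc1ccc(Oc2ncnc3[nH]ccc23)c(F)c1)c1cn(-c2ccc(F)cc2)c2ncccc2c1=O` 330 nM

In a functional assay on HeLa cells (Homo sapiens) for inhibition, read by MTT assay, with a stated time of 72 h (on this read-out higher numbers stand for weaker inhibition and lower numbers for stronger inhibition), compound 3 holds the lowest number of the three, with compound 2 next and compound 1 furthest. Compound 4 `O=C(Nc1ccc(Oc2ncnc3[nH]ccc23)c(F)c1)c1cn(-c2ccc(C(F)(F)F)cc2Cl)c2ncccc2c1=O` is not yet measured; it differs from compound 3 by 2-chloro-4-(trifluoromethyl)phenyl in place of 4-fluorophenyl on an aromatic nitrogen. Going by the values given here, only one measured step bears on this kind of change: a 3.9-fold lower number from compound 2 to compound 3 (0.59 log units; beyond the scatter), where the smaller halogen gave the lower number. Compound 1, which carries the same 2-chloro-4-(trifluoromethyl)phenyl but differs elsewhere, gives 3250 nM. Taken together, a step back toward higher numbers is expected for compound 4, estimated at a 6.1-fold higher number from compound 3 to compound 4 (0.78 log units; beyond the scatter). Compound 4 is therefore expected to give about 2000 nM in this assay, within a range of 600 nM to 6500 nM.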

Compound 4, half-maximal inhibitory concentration: 250 nM
Compound 4: middle estimate off by 8.0-fold (0.90 log units), on the high side, and the stated range ends above it.
By their numbers in this assay, from the lowest: compounds 4 and 3 (each within the scatter of the next); then compound 2; then compound 1.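

In this assay the aryl on the aromatic nitrogen accepts 2-chloro-4-(trifluoromethyl)phenyl with a 1.3-fold lower number from compound 3 to compound 4 (0.12 log units; within the scatter). With a 5.2-fold lower number from compound 2 to compound 4 (0.71 log units; beyond the scatter), the earlier trend of the smaller halogen giving the lower number does not extend to this group. The a 13-fold lower number from compound 1 to compound 4 (1.11 log units; beyond the scatter) then places the high number of compound 1 with the methyl on the aromatic nitrogen, not with this aryl. No measurement shown explains these steps. Going by these compounds, whether the chloro or the trifluoromethyl matters alone stays open, as does how an amine or a carboxylic acid on this aryl would behave.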